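Swapping the aryl group on a shared core: from dichloro to trifluoromethyl

A few compounds are considered here, and "the series" means these few. Any claim that something is new, unique, unknown or untested is made for them only; others in the source may bear on it.

Measured so far:
Compound 1 `O=C(Cn1nnc(-c2ccccc2)n1)Nc1ccccn1`: in an assay on HEK293 cells for activation of Kir3.1/Kir3.2 (Homo sapiens), read by thallium flux (a lower number here means a smaller maximal response, a higher number a larger maximal response), compound 1 gives "not active" (no number reported).
Compound 2 `Cc1cc(NC(=O)Cn2nnc(-c3ccc(Cl)c(Cl)c3)n2)n(C2CCCCC2)n1`: in this assay compound 2 gives 84%.

Going by the values given here, compound 2 stands as the only entry with a number in this assay; compound 1 gives no number at all. Compound 3 `Cc1cc(NC(=O)Cn2nnc(-c3cccc(C(F)(F)F)c3)n2)n(C2CCCCC2)n1` keeps the whole of compound 2 apart from one change: 3-(trifluoromethyl)phenyl in place of 3,4-dichlorophenyl on an aromatic carbon. Among the compounds with values here, no measured pair shows what this change does, so the expected step is a modest one, if any, likely downward or within scatter. Compound 3 is estimated at 75%, in the range 50% to 100%, an expected step of a number 9 percentage points lower from compound 2 to compound 3 (within the scatter).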

Compound 3, largest response reached (Emax), in percent of the reference or control that the assay uses: 86%
Compound 3: the middle estimate sits 11 percentage points below what was measured, and the stated range covers the measured number.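

In this assay, the step is a number 2 percentage points higher from compound 2 to compound 3 (within the scatter) when 3-(trifluoromethyl)phenyl takes the place of 3,4-dichlorophenyl on an aromatic carbon. This first pair differing in one place shows that, at this position, the two groups cannot be told apart in maximal response, even though the entering group has more heavy atoms. No measurement available here accounts for this result. Both groups are phenyl rings carrying halogen atoms. Still open, from the compounds shown here alone, is whether the response would hold with an amine or a carboxylic acid on that ring.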